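Amide substituent survey on the shared core

This account rests on a few compounds, and the source may have more. Where it says the series, first, only, none or still open, it means among the compounds named here.

Compound 3 `CC1CCCC(C(=O)N2CCc3nc(C#Cc4ccccc4)sc3C2)C1` stands in an assay on HEK293 cells for negative allosteric modulation of metabotropic glutamate receptor 5 (Homo sapiens), read by FLIPR, with a stated time of 1 h (on this read-out higher numbers stand for weaker inhibition and lower numbers for stronger inhibition), only as a limit: it gives > 10000 nM, which is a limit rather than a number. Compound 1 `COC1CC(C(=O)N2CCc3nc(C#Cc4ccccc4)sc3C2)C1` gives a limit of > 10000 nM in this assay. Compound 2 `CC1CCC(C(=O)N2CCc3nc(C#Cc4ccccc4)sc3C2)CC1` likewise gives a limit of > 10000 nM. All three sit at the limit of > 10000 nM in this assay, at which 3 of the 3 values shown sit, so the steps a step that the two limits leave unreadable from compound 1 to compound 3 and a step that the two limits leave unreadable from compound 2 to compound 3, as well as a step that the two limits leave unreadable from compound 1 to compound 2, cannot be read in size or direction. Compound 4 `O=C(N1CCCC1)N1CCc2nc(C#Cc3ccccc3)sc2C1` differs from compound 3 by pyrrolidin-1-yl in place of 3-methylcyclohexyl on a carbonyl carbon. Within the data shown here, no measured step gives a readable size for this change, so compound 4 is expected to remain near the same limit, with the step of an at least 1.1-fold lower number from compound 3 to compound 4 (0.04 log units; that floor lies within the scatter) an estimate only. Compound 4 is estimated at 9000 nM, between 2000 nM and 40000 nM.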

Compound 4, half-maximal inhibitory concentration: > 10000 nM
Compound 4: no number, only a limit; the forecaster's own chance of this, stated with the estimate: 60%; at least 1.1-fold (0.04 log units) between middle value and limit.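

Compound 4 also stands only as a limit, so no step from compound 1, compound 2 or compound 3 to compound 4 can be read in this assay: the limit of > 10000 nM in this assay, at which 4 of the 4 values shown sit.

The compounds shown leave open which amide substituent on the shared core, if any, gives a measurable number in this assay.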